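The source may report more compounds than this note shows. Statements on the series, on what has been measured and on what is new or still open speak of the compounds shown alone.

Measured so far in an ADME assay on Huh-5-2 cells (Homo sapiens) for cytotoxicity, read by WST assay, with a stated time of 3 days; on this read-out lower numbers stand for higher toxicity in this test and higher numbers for lower toxicity in this test:
compound 1, `O=c1c(O)c(-c2ccccc2)oc2cc(OCc3ccccc3[N+](=O)[O-])cc(O)c12`, 32000 nM;
compound 2, `Cc1ccccc1COc1cc(O)c2c(=O)c(O)c(-c3ccccc3)oc2c1`, 17000 nM;
compound 3, `O=c1c(O)c(-c2ccccc2)oc2cc(OCc3ccc([N+](=O)[O-])cc3)cc(O)c12`, 93000 nM.

Compound 4, `Cc1ccc(COc2cc(O)c3c(=O)c(O)c(-c4ccccc4)oc3c2)cc1`, awaits this assay. It differs from compound 3 by methyl in place of nitro on an aromatic carbon. That change has one measured precedent, from compound 1 to compound 2, (methyl in place of nitro on an aromatic carbon), which gave a 1.9-fold lower number from compound 1 to compound 2 (0.27 log units; within the scatter). The two cores differ by 4-nitrophenyl in place of 2-nitrophenyl on a saturated chain carbon bound to an oxygen on an aromatic ring. The surroundings also differ, ortho to a large group in the first pair against para to a large group here, so this is the same kind of change rather than the same one. Compound 3 stands highest of the three, with a 2.9-fold higher number from compound 1 to compound 3 (0.46 log units; beyond the scatter) and a 5.5-fold higher number from compound 2 to compound 3 (0.74 log units; beyond the scatter). The step to compound 4 is expected to be about a 1.6-fold lower number from compound 3 to compound 4 (0.19 log units; within the scatter) because a 1.9-fold lower number from compound 1 to compound 2 (0.27 log units; within the scatter) lay within the scatter. Compound 4 is therefore estimated at 60000 nM in this assay, expected between 25000 nM and 150000 nM.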

Compound 4, half-maximal cytotoxic concentration: 88000 nM
Estimate against measurement, compound 4: 1.5-fold (0.17 log units) below; low and high end bracket the measured number.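

Methyl in place of nitro carries across the two cores in this assay without a detectable difference: the same change on two cores in this assay, a 1.9-fold lower number (0.27 log units; within the scatter) from compound 1 to compound 2 and a 1.1-fold lower number (0.02 log units; within the scatter) from compound 3 to compound 4, 1.8-fold (0.25 log units) apart, within the scatter of two such steps

On the 4-nitrophenyl core the change gives a 1.1-fold lower number from compound 3 to compound 4 (0.02 log units; within the scatter), while the larger steps come with the other swaps, 4-methylphenyl in place of 2-methylphenyl giving a 5.2-fold higher number from compound 2 to compound 4 (0.71 log units; beyond the scatter) and 4-methylphenyl in place of 2-nitrophenyl giving a 2.8-fold higher number from compound 1 to compound 4 (0.44 log units; beyond the scatter). Among the compounds shown here, this agreement rests on only two pairs, neither with a step beyond the scatter, so it shows that the change did little on these two cores, not that a sizeable effect would transfer or that the result extends to other cores.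

As far as these compounds go, how an amine, a carboxylic acid or a chloro group in place of nitro would read in this assay remains open.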